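Amine side chain: from compound 2 to compound 3

The source may hold more compounds than are shown below. What is called first, only, known or untested is meant among the compounds shown, and "the series" means these compounds.

- compound 1 `CCN(CC)CCNC(=O)c1ccc(C(CC)(CC)c2ccc(OCC(=O)C(C)(C)C)c(C)c2)n1CC`: 2500 nM
- compound 2 `CCn1c(C(=O)NCCN(C)C)ccc1C(CC)(CC)c1ccc(OCC(=O)C(C)(C)C)c(C)c1`: 2500 nM

Both values come from an ADME assay on L02 cells (Homo sapiens) for cytotoxicity, read by MTT assay, with a stated time of 48 h; on this read-out lower numbers stand for stronger inhibition and higher numbers for weaker inhibition. For the measured compounds named here, at 2500 nM, compound 2 stands level with its only neighbour at the digits reported, the step being no change at the digits printed from compound 1 to compound 2 (within the scatter).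

The next compound, compound 3 `CCn1c(C(=O)NCCCN(C)C)ccc1C(CC)(CC)c1ccc(OCC(=O)C(C)(C)C)c(C)c1`, differs from compound 2 as follows: (dimethylamino)methyl in place of dimethylamino on a saturated chain carbon, two bonds along the chain from an amide-type nitrogen. The same difference reads (2-(dimethylamino)ethyl)amino to (3-(dimethylamino)propyl)amino.

Going by the values given here, only one measured step bears on this change, no change at the digits printed from compound 1 to compound 2 (within the scatter), and it alters the amine at the same place, not the chain that carries it. Among the compounds with values here, no measured pair tests the chain itself, so the evidence is indirect. Within the data shown here, the one step available is small, and neither direction is favoured, so no shift beyond the scatter is expected in this assay. The expected step is no change at the digits printed from compound 2 to compound 3 (within the scatter). For compound 3 the estimated value is 2500 nM, with an expected range of 1100 nM to 5500 nM.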

Compound 3, half-maximal inhibitory concentration: 670 nM
The estimate for compound 3 lay 3.7-fold (0.57 log units) above the measured number; measured number below the stated range.
By their numbers in this assay, from the lowest: compound 3; then compounds 1 and 2 (each within the scatter of the next).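

In this assay the chain that carries the amine now shows an effect where the amine itself showed none: (2-(dimethylamino)ethyl)amino to (3-(dimethylamino)propyl)amino gives a 3.7-fold lower number from compound 2 to compound 3 (0.57 log units; beyond the scatter), whereas dimethylamino in place of diethylamino on the shorter chain gave no change at the digits printed from compound 1 to compound 2 (within the scatter). The 3-(dimethylamino)propyl side chain also separates from the diethylamino one, with a 3.7-fold lower number from compound 1 to compound 3 (0.57 log units; beyond the scatter), so on this saturated chain carbon, two bonds along the chain from an amide-type nitrogen, the extra chain carbon counts for more than the change in the groups on the amine, a reading that rests on these three compounds alone. Nothing available explains the shift.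

Open, on these data alone, is whether a longer chain, such as 4-(dimethylamino)butyl, would carry the change further, hold it or reverse it. Also open, as far as these compounds go, is whether the amine still makes no difference on the longer chain, as a 3-(diethylamino)propyl side chain or a ring amine such as a 3-(pyrrolidin-1-yl)propyl side chain would show.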